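From Carbamoyl to 2-Carboxyethyl on a Shared Core

A few compounds are considered here, and "the series" means these few. Any claim that something is new, unique, unknown or untested is made for them only; others in the source may bear on it.

Compound 1 `COc1ccc(-c2nc(N=C(N)N)sc2-c2ccc(OC)cc2)cc1` gives 31000 nM in a functional assay with Oryctolagus cuniculus as the target; a lower number here means a stronger inhibitor, a higher number a weaker inhibitor. Compound 2 `COc1ccc(-c2nc(C(N)=O)sc2-c2ccc(OC)cc2)cc1` is reported only as a limit of this assay, > 1000 nM. The step that the limit leaves unreadable from compound 1 to compound 2 therefore cannot be read, as the limit of > 1000 nM in this assay, at which 1 of the 2 values shown sits, shows. Compound 3 `COc1ccc(-c2nc(CCC(=O)O)sc2-c2ccc(OC)cc2)cc1` carries 2-carboxyethyl in place of carbamoyl on an aromatic carbon. Among the compounds with values here, no measured step covers this change, and the single known step is unreadable, so neither direction nor size in this assay can be anticipated from these numbers. The expected step that the limit leaves unreadable from compound 2 to compound 3 is accordingly centred on no change. Compound 3 is expected to give 5000 nM, within 1000 nM to 30000 nM.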

Compound 3, half-maximal inhibitory concentration: < 100 nM
Compound 3: only a limit was reported; the forecaster's own chance of this, stated with the estimate: 50%; at least 50-fold (1.69 log units) between middle value and limit.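

Within the data shown here, at this position on the shared core, 2-carboxyethyl in place of carbamoyl gives the first readable step in this assay, with an at least 10-fold lower number from compound 2 to compound 3 (1.00 log units; beyond the scatter). Set against the group on compound 1, the same position shows an at least 310-fold lower number from compound 1 to compound 3 (2.49 log units; beyond the scatter), so the group placed here clearly moves the number. Each size is only a bound, because compound 3 is reported as a limit: the limit of < 100 nM in this assay, at which 1 of the 3 values shown sits.

As far as these compounds go, whether the change follows the carboxylic acid end or the length of the chain stays open. A shorter carboxymethyl group, or an amine at the end of the same chain, would help separate the two.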